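This account rests on a few compounds, and the source may have more. Where it says the series, first, only, none or still open, it means among the compounds named here.

Compound 1 `COc1ccc(OCC2=NCCO2)cc1` stands highest of the two numbers shown: in a functional assay on the whole organism for inhibition, with Rattus norvegicus as the target, read by paw edema, with a stated time of 30 min, at a dose of 20 mg/kg by the oral route (a lower number here means a weaker effect, a higher number a stronger effect of the compound at the dose given), compound 1 gives 16.6%, while compound 2 `Cc1ccccc1OCC1=NCCO1` gives 3.1%, a gap beyond the scatter. Compound 3 `Brc1ccc(OCC2=NCCO2)cc1` has not yet been measured in this assay. It differs from compound 1 by bromo in place of methoxy on an aromatic carbon. Among the compounds with values here, no measured pair shows the effect of such a change, so the direction is open, and a step of modest size, or none beyond the scatter, seems the likeliest outcome. Compound 3 is expected to give 15%, with a range from 0% to 35%. That estimate means an expected step of a number 1.6 percentage points lower from compound 1 to compound 3 (within the scatter).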

Compound 3, a percentage reported as inhibition, in the whole organism at one dose (the size of the read-out at that dose, not a potency): 35.5%
Compound 3: the middle estimate sits 20.5 percentage points below what was measured; measured number above the stated range.
By their numbers in this assay, from the lowest: compound 2; then compound 1; then compound 3.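

In this assay, bromo in place of methoxy gives a number 18.9 percentage points higher from compound 1 to compound 3 (beyond the scatter). Within the data shown here, this is the first pair differing in one place, and it shows that the read-out at this dose responds to what the aromatic carbon carries at this position. No measurement bears on why the step arises.

Going by these compounds, how chloro, trifluoromethyl or an amine would fare at this same position stays open, so one pair cannot show whether the step is specific to bromo. On these data alone, whether it would hold at other doses or times also remains open.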